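Crotonamide series: nitro replaced by fluoro beside methoxy

The source may hold more compounds than are shown below. What is called first, only, known or untested is meant among the compounds shown, and "the series" means these compounds.

Measured so far:
compound 1 `C/C=C/C(=O)N(Cc1ccc(OC)c([N+](=O)[O-])c1)c1cc(OC)c(OC)c(OC)c1` gives 590 nM in a functional assay on MGC-803 cells (Homo sapiens) for inhibition, read by MTT assay, with a stated time of 48 h; a higher number here means a weaker inhibitor, a lower number a stronger inhibitor.
compound 2 `COc1ccc(CNc2cc(OC)c(OC)c(OC)c2)cc1[N+](=O)[O-]` gives 19400 nM in this assay.
compound 3 `COc1cc(NCc2ccc(Cl)cc2)cc(OC)c1OC` reaches only the limit > 80000 nM in this assay.

Going by the values given here, compound 1 stands lowest of the two numbers; the single measured step, a 33-fold higher number from compound 1 to compound 2 (1.52 log units; beyond the scatter), concerns the amide nitrogen and not the benzyl ring. the limit of > 80000 nM in this assay, at which 1 of the 3 values shown sits, belongs to compound 3 alone and gives no step. Compound 4 `C/C=C/C(=O)N(Cc1ccc(OC)c(F)c1)c1cc(OC)c(OC)c(OC)c1` differs from compound 1 by fluoro in place of nitro on an aromatic carbon. Among the compounds with values here, no measured step bears on this position, so no large step is expected in this assay; a modest weakening is estimated, a 2.5-fold higher number from compound 1 to compound 4 (0.41 log units; beyond the scatter). Compound 4 is expected to give 1500 nM (range 400 nM to 6000 nM).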

Compound 4, half-maximal inhibitory concentration: 1650 nM
Beside the measured number, compound 4's estimate is 1.1-fold (0.04 log units) below it; the range from low to high includes it.
By their numbers in this assay, from the lowest: compound 1; then compound 4; then compound 2. At a limit, above all of these: compound 3.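

Fluoro in place of nitro on the aromatic carbon ortho to a methoxy group gives a 2.8-fold higher number from compound 1 to compound 4 (0.45 log units; beyond the scatter) in this assay, the only measured step at this position. The nitro group is therefore not required for a measurable number here, although its loss costs a modest amount beyond the scatter.

No measured property among the data bears on the reason for this step. As far as these compounds go, how an amine or a nitrile would read at this position stays open, as does whether the change carries over to compounds lacking the (prop-1-en-1-yl)carbonyl group.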